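A few compounds are considered here, and "the series" means these few. Any claim that something is new, unique, unknown or untested is made for them only; others in the source may bear on it.

Measured in a functional assay on MGC-803 cells (Homo sapiens) for antiproliferative activity, read by MTT assay, with a stated time of 48 h; on this read-out higher numbers stand for weaker inhibition and lower numbers for stronger inhibition:
- Compound 1 `COc1cc(N(Cc2ccc(C)cc2)C(=O)CSc2nc3ccccc3s2)cc(OC)c1OC`: 54200 nM
- Compound 2 `COc1ccc(CN(C(=O)CSc2nc3ccccc3s2)c2cc(OC)c(OC)c(OC)c2)cc1N=[N+]=[N-]`: 187 nM
- Compound 3 `COc1ccc(CN(C(=O)CSc2nc3ccccc3s2)c2cc(OC)c(OC)c(OC)c2)cc1Br`: 852 nM

Compound 3 sits in the middle of these three numbers. The unmeasured compound 4 `COc1ccc(CN(C(=O)CSc2nc3ccccc3s2)c2cc(OC)c(OC)c(OC)c2)cc1C(F)(F)F` carries trifluoromethyl in place of bromo on an aromatic carbon. The closest evidence is a swap on that same carbon, a 4.6-fold higher number from compound 2 to compound 3 (0.66 log units; beyond the scatter). The larger steps, a 64-fold lower number from compound 1 to compound 3 (1.80 log units; beyond the scatter) and a 290-fold lower number from compound 1 to compound 2 (2.46 log units; beyond the scatter), replace the whole 4-methylphenyl group and so bear less directly. Among the compounds with values here, only one swap on that carbon has been measured, so a small upward step is expected, perhaps not beyond the scatter. The estimated step is a 1.8-fold higher number from compound 3 to compound 4 (0.25 log units; within the scatter). For compound 4 the expected value is 1500 nM, with an estimated range of 400 nM to 6000 nM.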

Compound 4, half-maximal inhibitory concentration: 25200 nM
Compound 4: the middle estimate sits 17-fold (1.23 log units) below what was measured, outside the stated range (above it).
By their numbers in this assay, from the lowest: compound 2; then compound 3; then compound 4; then compound 1.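

Within the data shown here, on this aromatic carbon the choice of group matters far more than the one earlier swap suggested: a 30-fold higher number from compound 3 to compound 4 (1.47 log units; beyond the scatter) and a 130-fold higher number from compound 2 to compound 4 (2.13 log units; beyond the scatter) show that trifluoromethyl loses most of the strength seen with bromo and azido. Only a 2.2-fold lower number from compound 1 to compound 4 (0.33 log units; beyond the scatter) remains, so 4-methoxy-3-(trifluoromethyl)phenyl keeps little of the gain that the other two rings brought over 4-methylphenyl. Nothing measured here accounts for this sharp drop.

Still open, going by these compounds, is whether a chloro, a nitrile or an amine on this carbon would land nearer compound 2 or compound 4.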